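This account rests on a few compounds, and the source may have more. Where it says the series, first, only, none or still open, it means among the compounds named here.

In a functional assay (aorta) with Rattus norvegicus as the target (a lower number here means that less compound is needed, a higher number that more compound is needed for the effect), three compounds with a shared core have been measured. Compound 1 `CCCNC1=NS(=O)(=O)c2cc(F)ccc2N1` gives 166 uM. Compound 2 `O=S1(=O)NC(NC2CC2)=Nc2ccc(F)cc21` gives > 300 uM, which is a limit of the assay and not a number. Among the compounds with values here, compound 3 `O=S1(=O)NC(NC2CCC2)=Nc2ccc(F)cc21` gives 71.8 uM, the lower of the two actual numbers so far. The next compound is compound 4 `O=S1(=O)NC(NC2CCCC2)=Nc2ccc(F)cc21`, with this change from compound 3: cyclopentyl in place of cyclobutyl on an amine nitrogen. Put simply, cyclopentyl stands in place of cyclobutyl on an amine nitrogen. Within the data shown here, the only measured step of this kind is an at least 4.1-fold lower number from compound 2 to compound 3 (0.62 log units; beyond the scatter), with cyclobutyl in place of cyclopropyl on an amine nitrogen. A single step is a thin basis, but a further modest drop seems likely, and the estimated change is a 2.4-fold lower number from compound 3 to compound 4 (0.38 log units; beyond the scatter). For compound 4 the expected value is 30 uM, with an estimated range of 10 uM to 100 uM.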

Compound 4, concentration for half-maximal effect: 58 uM
Beside the measured number, compound 4's estimate is 1.9-fold (0.29 log units) below it, and the stated range covers the measured number.
By their numbers in this assay, from the lowest: compounds 4 and 3 (each within the scatter of the next); then compound 1. At a limit, above all of these: compound 2.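

In this assay, cyclopentyl in place of cyclobutyl on the amine nitrogen gives a 1.2-fold lower number from compound 3 to compound 4 (0.09 log units; within the scatter), so the gain seen on going from cyclopropyl to cyclobutyl does not continue beyond the scatter. Cyclopentyl in place of cyclopropyl gives an at least 5.1-fold lower number from compound 2 to compound 4 (0.71 log units; beyond the scatter). The value of compound 2 is a limit and not a number: the limit of > 300 uM in this assay, at which 1 of the 4 values shown sits.

The compounds shown leave open whether a cyclohexyl ring would keep the number at this level. They also leave open how a branched chain such as isopropyl, or a hydroxyl group on the ring, would compare.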